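A few compounds are considered here, and "the series" means these few. Any claim that something is new, unique, unknown or untested is made for them only; others in the source may bear on it.

In an ADME assay on L6 cells (Rattus norvegicus) for cytotoxicity, read by resazurin assay, with a stated time of 72 h (on this read-out lower numbers stand for stronger inhibition and higher numbers for weaker inhibition), two compounds that share a core have been measured. Compound 1 (`CN1CCN(CC(=O)NC2CC3(N(C)C)CC(c4ccccc4)C2C(c2ccccc2)C3)CC1`) gives 66200 nM. Compound 2 (`CN(C)C12CC(N)C(C(c3ccccc3)C1)C(c1ccccc1)C2`), with hydrogen in place of ((4-methylpiperazin-1-yl)methyl)carbonyl on an amine nitrogen, gives 40900 nM. Among the compounds with values here, these two values lie within the scatter of each other, so compound 2 cannot be separated from its only measured neighbour.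

Compound 3 (`CN(C)C12CC(OC(=O)CN3CCCCC3)C(C(c3ccccc3)C1)C(c1ccccc1)C2`) differs from compound 2 at that amino group, with (((piperidin-1-yl)methyl)carbonyl)oxy in place of amino on a saturated ring carbon.

Within the data shown here, the one measured step that bears on this change is a 1.6-fold lower number from compound 1 to compound 2 (0.21 log units; within the scatter). That step removed a comparable side chain and stayed within the scatter, which suggests that adding a chain here may also matter little. Among the measured compounds shown here, it is only a rough guide, since compound 1 holds its chain through nitrogen and compound 3 holds its chain through oxygen, and no measured compound shows the effect of that link. No change beyond the scatter is therefore expected, and the estimated step is a 1.2-fold lower number from compound 2 to compound 3 (0.07 log units; within the scatter). For compound 3 the estimated value is 35000 nM, with an expected range from 12000 nM to 90000 nM.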

Compound 3, half-maximal inhibitory concentration: 29300 nM
Beside the measured number, compound 3's estimate is 1.2-fold (0.08 log units) above it; measured number inside the range.
By their numbers in this assay, from the lowest: compounds 3, 2 and 1 (each within the scatter of the next, the first and the last beyond it).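

Replacing the small amino group with (((piperidin-1-yl)methyl)carbonyl)oxy, which has 10 heavy atoms, gives a 1.4-fold lower number from compound 2 to compound 3 (0.14 log units; within the scatter) in this assay and so leaves compound 2 and compound 3 inseparable, even though this saturated ring carbon now carries a much larger group held through oxygen. Within the data shown here, the result also allows the first comparison of two chains at this ring carbon, and a 2.3-fold lower number from compound 1 to compound 3 (0.35 log units; beyond the scatter) is a modest step, but it is the first one here beyond the scatter, so the choice of chain can shift the number slightly even though neither compound 1 nor compound 3 is separated from compound 2. That step swaps the nitrogen link for oxygen and the 4-methylpiperazine ring for piperidine together, so its size cannot be divided between those two differences.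

No measurement shown here explains these differences. Still open, going by these compounds, are the effect of the link alone, which would need the same chain held through nitrogen and through oxygen, and the effect of a morpholine ring, a carboxylic acid or a longer chain at this ring carbon.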